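A few compounds are considered here, and "the series" means these few. Any claim that something is new, unique, unknown or untested is made for them only; others in the source may bear on it.

Within the data shown here, compound 2 `CC(C)(Cc1ccc(F)cc1)C1OCC(C/C=C\CCC(=O)O)C(c2cccnc2)O1` is the one member of this small set with an actual number: in an assay for inhibition of prostacyclin synthase (Homo sapiens), using microsomes (on this read-out lower numbers stand for stronger inhibition and higher numbers for weaker inhibition), compound 2 gives 2000 nM. Compound 1 `CSc1ccccc1OC(C)(C)C1OCC(C/C=C\CCC(=O)O)C(c2cccnc2)O1` is different. In this assay compound 1 gives only > 100000 nM, which is a limit of the assay rather than a number. Among the measured compounds shown here, the single measured step, an at least 50-fold lower number from compound 1 to compound 2 (1.69 log units; beyond the scatter), places a 4-fluorobenzyl group in place of a 2-(methylsulfanyl)phenoxy group on a saturated chain carbon; because it rests on the limit of > 100000 nM in this assay, at which 1 of the 2 values shown sits, its true size is known only to be large. Compound 3 `CC(C)(Cc1ccc(F)cc1C#N)C1OCC(C/C=C\CCC(=O)O)C(c2cccnc2)O1` keeps the 4-fluorobenzyl group of compound 2 and adds (cyano in place of hydrogen on an aromatic carbon). For the measured compounds named here, no measured step touches the aromatic ring itself, so the one step offers no direct guide. For compound 3 the expected step is no change at the digits printed from compound 2 to compound 3 (within the scatter), estimated to stay within the scatter. Compound 3 is therefore expected to show 2000 nM, with a range from 500 nM to 8000 nM.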

Compound 3, half-maximal inhibitory concentration: 7000 nM
Estimate against measurement, compound 3: 3.5-fold (0.54 log units) below; the range from low to high includes it.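

In this assay, the aromatic ring of the 4-fluorobenzyl group turns out not to be indifferent to change: cyano on the aromatic carbon ortho to a large group and meta to a fluoro group gives a 3.5-fold higher number from compound 2 to compound 3 (0.54 log units; beyond the scatter). The loss is modest, and the replacement of the whole group still separates the two compounds clearly, with an at least 14-fold lower number from compound 1 to compound 3 (1.15 log units; beyond the scatter). That second step can be read only as a minimum, because one end of it is not a number: the limit of > 100000 nM in this assay, at which 1 of the 3 values shown sits.

Cyano alone on this carbon cannot show whether any added group would raise the number, and a chlorine atom, a methyl or an amine at the same place would test that. On these data alone, what the fluoro group itself contributes also stays open, and a plain phenyl ring in place of 2-cyano-4-fluorophenyl would bear on it.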